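Nitro in Place of Cyano: a Cytotoxicity Check

A few compounds are considered here, and "the series" means these few. Any claim that something is new, unique, unknown or untested is made for them only; others in the source may bear on it.

Compound 1 `N#Cc1cccc(C(=O)N2CCCC(C(=O)Nc3ccc(Cl)cc3)C2)c1` was tested in an ADME assay on PC-3 cells (Homo sapiens) for cytotoxicity, read by WST assay, tested at 100 uM (a lower number here means less inhibition, a higher number more inhibition at the concentration tested (going by the name of the read-out)), where compound 1 gives 0%. Compound 2 `O=C(Nc1cccc(Oc2ccccc2)c1)C1CCCN(C(=O)c2cccc(-c3ccco3)c2)C1` shows a level reading in this assay, with compound 2 at 0%; the two values lie within the scatter of each other. Compound 3 `O=C(Nc1ccc(Cl)cc1)C1CCCN(C(=O)c2cccc([N+](=O)[O-])c2)C1` has not yet been measured. It differs from compound 1 by nitro in place of cyano on an aromatic carbon. Because compound 1 sits at 0%, the step of a number 2 percentage points higher from compound 1 to compound 3 (within the scatter) is expected to be none beyond the scatter. Compound 3 is therefore estimated at 2%, with a range from -8% to 15%.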

Compound 3, a percentage reported as inhibition, at one concentration (the size of the read-out at that concentration, not a potency): 0%
Compound 3: the middle estimate sits 2 percentage points above what was measured, and the stated range covers the measured number.
By their numbers in this assay, from the lowest: compounds 1, 2 and 3 (each within the scatter of the next).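

In this assay, the 3-cyanophenyl to 3-nitrophenyl change gives no change at the digits printed from compound 1 to compound 3 (within the scatter). Among the compounds shown here, this is the first comparison here that isolates a single place, showing that on this aromatic carbon, meta to a large group, nitro in place of cyano leaves the reading unmoved within the scatter. No available measurement speaks to the reason for this. Open still is how this assay would read with an amine or a carboxylic acid at this place. Also open, from the compounds shown here alone, is whether the same exchange would behave alike on the core of compound 2.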